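The compounds below may be only part of what the source reports. "The series", "measured", "known", "first", "only" and "open" are said of these compounds alone.

Working notes on the amine series. Compound 1 `COc1cccc(NC2=CC(=O)c3c(nc4n3[C@H]3OC[C@@H](O)[C@H]3OC4)C2=O)c1`, compound 2 `Cc1ccc(NC2=CC(=O)c3nc4n(c3C2=O)[C@H]2OC[C@@H](O)[C@H]2OC4)cc1C` and compound 3 `COc1ccc(NC2=CC(=O)c3nc4n(c3C2=O)[C@H]2OC[C@@H](O)[C@H]2OC4)cc1` share one core and differ only in the group on the amine nitrogen. In a functional assay on MGC-803 cells (Homo sapiens) for inhibition, read by sulforhodamine B assay (a higher number here means a weaker inhibitor, a lower number a stronger inhibitor), compound 1 gives 1790 nM, compound 2 gives 860 nM and compound 3 gives 1680 nM. Compound 1 thus carries the highest number of the three; against compound 3 the gap lies within the scatter, whereas compound 2 sits at a lower number beyond it. Going by the values given here, the one single-point step available is a 2.0-fold higher number from compound 2 to compound 3 (0.29 log units; within the scatter), an exchange of one aryl group for another that stays within the scatter.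

Compound 4 `O=C1C(NCc2ccccc2)=CC(=O)c2c1nc1n2[C@H]2OC[C@@H](O)[C@H]2OC1` is not yet measured. It differs from compound 1 by benzyl in place of 3-methoxyphenyl on an amine nitrogen. Among the compounds with values here, no measured step swaps an aryl group for a benzyl on this nitrogen, so the aryl-to-aryl step from compound 2 to compound 3 bears on it only loosely and suggests modest sensitivity to what sits on the nitrogen. No shift beyond the scatter is expected in this assay, but the range is left wide. Compound 4 is estimated at 2200 nM, between 700 nM and 7000 nM, the expected step being a 1.2-fold higher number from compound 1 to compound 4 (0.09 log units; within the scatter).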

Compound 4, half-maximal inhibitory concentration: 3490 nM
Beside the measured number, compound 4's estimate is 1.6-fold (0.20 log units) below it; low and high end bracket the measured number.
By their numbers in this assay, from the lowest: compounds 2, 3, 1 and 4 (each within the scatter of the next, the first and the last beyond it).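

The earlier compounds shown here only exchanged one aryl group for another on this amine nitrogen, whereas benzyl in place of 3-methoxyphenyl changes the kind of group attached there. In this assay, that change gives a 1.9-fold higher number from compound 1 to compound 4 (0.29 log units; within the scatter), so this pair shows no shift beyond the scatter even though the ring is no longer attached directly to the nitrogen and the methoxy group is gone. Going by these compounds alone, with only this pair, the result cannot separate the change from aryl to benzyl from the loss of the methoxy group, and no available evidence bears on the step.

From the compounds shown here alone, it remains open what a phenethyl chain or a cyclohexyl group on this nitrogen would give in this assay. Also open, going by these compounds, is whether a methoxy group on the benzyl ring would alter the number for compound 4.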